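The compounds below may be only part of what the source reports. "The series", "measured", "known", "first", "only" and "open" are said of these compounds alone.

Measured compounds in the series:

- Compound 1, `CC(=O)c1cc(C(=O)N[C@@H](C)Cn2ccc(-c3cc(F)c(C#N)c(Cl)c3)n2)n[nH]1` — compound 1 gives "not determined" (no result reported) in a functional assay on VCaP cells (Homo sapiens) for antiproliferative activity, read by CCK-8 assay, with a stated time of 6 days; a higher number here means a weaker inhibitor, a lower number a stronger inhibitor
- Compound 2, `CC(=O)c1ccc(C(=O)N[C@@H](C)Cn2ccc(-c3ccc(C#N)c(Cl)c3)n2)cc1` — compound 2 gives 1400 nM in this assay
- Compound 3, `C[C@@H](Cn1ccc(-c2ccc(C#N)c(Cl)c2)n1)NC(=O)c1ccccc1F` — compound 3 gives 2190 nM in this assay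

For the measured compounds named here, compound 3 has the highest of the two numbers in hand; its nearest neighbour is compound 2, and the only single-point step available, a 1.6-fold higher number from compound 2 to compound 3 (0.19 log units; within the scatter), lies within the scatter, so compound 3 and compound 2 are not to be ranked against each other. Compound 1 contributes no number.

The next compound is compound 4, `C[C@@H](Cn1ccc(-c2ccc(C#N)c(Cl)c2)n1)Nc1nccc(Cl)n1`. Relative to compound 3 the change is 4-chloropyrimidin-2-yl in place of (2-fluorophenyl)carbonyl on an amine nitrogen. Going by the values given here, this touches a part of the molecule that none of the measured steps alters: the step of a 1.6-fold higher number from compound 2 to compound 3 (0.19 log units; within the scatter) exchanges only the aryl group on the carbonyl carbon, and the carbonyl itself is kept there. Among the compounds with values here, no measured step therefore bears on the exchange of the whole (2-fluorophenyl)carbonyl for 4-chloropyrimidin-2-yl on the amine nitrogen, and no direction can be read off the data.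

With nothing to anchor a shift, the expected step of a 1.1-fold higher number from compound 3 to compound 4 (0.06 log units; within the scatter) is taken as none beyond the scatter, with a wide range. For compound 4 the estimate in this assay is 2500 nM, between 600 nM and 10000 nM.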

Compound 4, half-maximal inhibitory concentration: > 30000 nM
Compound 4: a limit, no number; the forecaster's own chance of this, stated with the estimate: 15%; middle value at least 12-fold (1.07 log units) from the limit.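

In this assay compound 4 gives > 30000 nM, which is a limit of the assay and not a number. Putting 4-chloropyrimidin-2-yl in place of (2-fluorophenyl)carbonyl on the amine nitrogen gives an at least 13-fold higher number from compound 3 to compound 4 (1.13 log units; beyond the scatter), the only step shown that lies beyond the scatter, whereas the exchange of the aryl group with the carbonyl kept, a 1.6-fold higher number from compound 2 to compound 3 (0.19 log units; within the scatter), lies within it. This amine nitrogen is therefore sensitive to what it carries, in a way the pair that keeps the carbonyl did not show, and the true size of the step stays unknown, since the value rests on the limit: the limit of > 30000 nM in this assay, at which 1 of the 4 values shown sits.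

The single change removes the carbonyl and exchanges the ring together, so the compounds shown do not tell which of the two carries the step; a 2-fluorophenyl on the amine nitrogen with no carbonyl, or a pyrimidine ring on the carbonyl carbon, would separate them. Also open, on these data alone, is whether the chlorine counts, which a plain pyrimidin-2-yl on the amine nitrogen would address.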